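The compounds below may be only part of what the source reports. "The series", "measured", "known", "first", "only" and "open" are said of these compounds alone.

Measured compounds:
compound 1 `COCCNC(=O)[C@H]1CC[C@@H](Nc2ncc3c(Br)nn(-c4ccc5ncccc5c4)c3n2)C1` gives 61 nM in an assay on isolated protein for inhibition of eIF-2-alpha kinase GCN2 (Homo sapiens); a higher number here means a weaker inhibitor, a lower number a stronger inhibitor
compound 2 `COCCNC(=O)[C@H]1CC[C@H](Nc2ncc3c(Br)nn(-c4ccc5ncccc5c4)c3n2)C1` gives 144 nM in this assay
compound 3 `COCCNC(=O)[C@@H]1CC[C@@H](Nc2ncc3c(Br)nn(-c4ccc5ncccc5c4)c3n2)C1` gives 5 nM in this assay

Compound 3 carries the lowest number of the three: a 12-fold lower number from compound 1 to compound 3 (1.09 log units; beyond the scatter) and a 29-fold lower number from compound 2 to compound 3 (1.46 log units; beyond the scatter) are both beyond the scatter, while a 2.4-fold higher number from compound 1 to compound 2 (0.37 log units; beyond the scatter) is modest. All three steps are changes of configuration only (the fact that compounds 1 and 2 differ only in the configuration as drawn, (the fact that compounds 1 and 3 differ only in the configuration as drawn), (the fact that compounds 2 and 3 differ only in the configuration as drawn)).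

Compound 4 `COCCC(=O)N[C@@H]1CC[C@@H](Nc2ncc3c(Br)nn(-c4ccc5ncccc5c4)c3n2)C1` differs from compound 3 by ((2-methoxyethyl)carbonyl)amino in place of (2-methoxyethyl)carbamoyl on a saturated ring carbon, the amide being turned around. Among the compounds with values here, none of the measured steps alters how the atoms are joined, so none bears directly on this change; they show only how strongly the outcome in this assay depends on configuration. Within the data shown here, with no step in hand on the amide, the expectation for compound 4 is a number near that of compound 3, a 1.8-fold higher number from compound 3 to compound 4 (0.26 log units; within the scatter), with wide uncertainty. Compound 4 is estimated at 9 nM, range 3 nM to 30 nM.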

Compound 4, half-maximal inhibitory concentration: 74 nM
Compound 4: middle estimate off by 8.2-fold (0.91 log units), on the low side; the whole stated range lies below it.
By their numbers in this assay, from the lowest: compound 3; then compounds 1, 4 and 2 (each within the scatter of the next, the first and the last beyond it).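

In this assay the reversed amide on the saturated ring carbon gives a clear loss (a 15-fold higher number from compound 3 to compound 4 (1.17 log units; beyond the scatter)), although ((2-methoxyethyl)carbonyl)amino and (2-methoxyethyl)carbamoyl hold the same heavy atoms. Within the data shown here, the outcome at this position therefore depends on the direction of the amide as well as on configuration, the only feature varied among compounds 1, 2 and 3. Nothing in hand bears on the reason for this step.

Open, on these data alone, is whether the other stereoisomers of the reversed amide keep the order seen for compounds 1, 2 and 3. Also open, as far as these compounds go, is whether an amine, a carboxylic acid or a longer chain at this ring carbon would fall nearer compound 3 or compound 4.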